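A Larger Ester Tail in Place of Cyclobutyl

The source may report more compounds than this note shows. Statements on the series, on what has been measured and on what is new or still open speak of the compounds shown alone.

Compound 1 `NC(=O)c1c(NC(=O)Nc2ccc(Cl)cc2)sc2c1CCN(CC1CCC1)C2` stands lowest of the two numbers in hand: in a functional assay (strain AB) with Danio rerio as the target, read by microscopy, with a stated time of 1 h (on this read-out lower numbers stand for an effect already at smaller amounts and higher numbers for an effect only at larger amounts of compound), compound 1 gives 1360 nM. For the measured compounds named here, compound 2 `CCN1CCc2sc(NC(=O)Nc3ccc(Cl)cc3)c(C(N)=O)c2CC1`, the only other measured compound, gives 5800 nM in this assay, a higher number lying beyond the scatter. Compound 3 `CC(C)(C)OC(=O)CCCCCN1CCc2c(sc(NC(=O)Nc3ccc(Cl)cc3)c2C(N)=O)C1` differs from compound 1 by 4-(tert-butoxycarbonyl)butyl in place of cyclobutyl on a saturated chain carbon bound to an amine nitrogen in a ring. Going by the values given here, no measured pair shows a change of this kind, so the step of a 1.6-fold higher number from compound 1 to compound 3 (0.21 log units; within the scatter) is expected to be small, a modest rise at most, close to the scatter. Compound 3 is therefore estimated at 2200 nM, with a range from 700 nM to 7000 nM.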

Compound 3, half-maximal effective concentration: 620 nM
Compound 3: middle estimate off by 3.5-fold (0.55 log units), on the high side; measured number below the stated range.
By their numbers in this assay, from the lowest: compound 3; then compound 1; then compound 2.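

In this assay, this place on a saturated chain carbon bound to an amine nitrogen in a ring tolerates a much larger group: 4-(tert-butoxycarbonyl)butyl, with 11 heavy atoms and no ring, replaces cyclobutyl, with 4 heavy atoms, and gives a 2.2-fold lower number from compound 1 to compound 3 (0.34 log units; beyond the scatter). In this single pair, the four-membered ring is not needed to keep the number low. Nothing available explains the change.

On these data alone, whether the step comes from the tert-butyl ester or from the chain alone remains open. A plain hexyl chain or the free carboxylic acid at this place would separate the two.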